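This account rests on a few compounds, and the source may have more. Where it says the series, first, only, none or still open, it means among the compounds named here.

Of the compounds shown here, two have so far been measured in an assay on HEK293 cells for inhibition of transient receptor potential cation channel subfamily V member 1 (Homo sapiens), read by FLIPR; on this read-out higher numbers stand for weaker inhibition and lower numbers for stronger inhibition. Within the data shown here, compound 1, `Cc1ccc(N2CCN(C(=O)Nc3ccc(C(C)C)cc3)CC2)nn1`, is the first of them. In this assay compound 1 reaches only the limit of the assay, > 10000 nM, and not a number. Compound 2, `CC(C)(C)c1ccc(NC(=O)N2CCN(c3nncc4ccccc34)CC2)cc1`, is the starting point of the step followed here. In this assay compound 2 likewise gives only the limit, > 10000 nM. Where compound 2 stands is thus fixed by the limit of > 10000 nM in this assay, at which 2 of the 2 values shown sit, and no step between measured compounds can be sized from this. Compound 3, `O=C(Nc1ccc(OC(F)(F)F)cc1)N1CCN(c2nncc3ccccc23)CC1`, is not yet measured; it differs from compound 2 by trifluoromethoxy in place of tert-butyl on an aromatic carbon. With nothing but limits to rest on, the expected step is a number no higher from compound 2 to compound 3 (the limit leaves the size open), nothing beyond the scatter. Compound 3 is accordingly expected to give about 10000 nM in this assay, between 3000 nM and 30000 nM, most likely again as a limit only.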

Compound 3, half-maximal inhibitory concentration: > 10000 nM
Compound 3: no number, only a limit; the forecaster's own chance of this, stated with the estimate: 80%; the middle value lies on the limit itself.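

Among these compounds, compound 3 stops at the limit of the assay, as compound 2 does, so no step from one to the other can be read: the limit of > 10000 nM in this assay, at which 3 of the 3 values shown sit. The compounds shown leave open how tert-butyl and trifluoromethoxy compare, and what would give a measured number rather than a limit.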